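From compound 3 to compound 4: adding a single fluoro

The compounds below may be only part of what the source reports. "The series", "measured", "known", "first", "only" and "open" are said of these compounds alone.

compound 1 `C=C1C(=O)O[C@@H]2CC(C)=C([C@@H](C)CCCOC(C)=O)[C@@H](OC(=O)CN(CC)CC)[C@H]12`: 13100 nM
compound 2 `C=C1C(=O)O[C@@H]2CC(C)=C([C@@H](C)CCCOC(C)=O)[C@@H](OC(=O)CN3CCCC3)[C@H]12`: 20500 nM
compound 3 `C=C1C(=O)O[C@@H]2CC(C)=C([C@@H](C)CCCOC(C)=O)[C@@H](OC(=O)c3ccccc3)[C@H]12`: 10500 nM

All three values come from a functional assay on HCT-116 cells (Homo sapiens) for cytotoxicity, read by sulforhodamine B assay, with a stated time of 72 h; on this read-out higher numbers stand for weaker inhibition and lower numbers for stronger inhibition. Compound 3 cannot be separated from the other two: the measured steps are a 1.2-fold lower number from compound 1 to compound 3 (0.10 log units; within the scatter) and a 2.0-fold lower number from compound 2 to compound 3 (0.29 log units; within the scatter). No order can be read among the three.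

Compound 4 `C=C1C(=O)O[C@@H]2CC(C)=C([C@@H](C)CCCOC(C)=O)[C@@H](OC(=O)c3cccc(F)c3)[C@H]12` differs from compound 3 by fluoro in place of hydrogen on an aromatic carbon. This places fluoro in place of hydrogen on an aromatic carbon, meta to a large group. Among the compounds with values here, no measured step covers a substitution on this phenyl ring, so the evidence is indirect. The two steps above exchange the whole group on the carbonyl carbon, and a 1.6-fold higher number from compound 1 to compound 2 (0.19 log units; within the scatter) changes only the amine. Given that compound 3 differs from compound 2 by only a 2.0-fold lower number from compound 2 to compound 3 (0.29 log units; within the scatter) after such an exchange, a single fluoro is expected to give no step beyond the scatter in this assay, with no direction favoured. The expected step is a 1.1-fold lower number from compound 3 to compound 4 (0.02 log units; within the scatter). For compound 4 the estimated value is 10000 nM, with an expected range of 5000 nM to 20000 nM.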

Compound 4, half-maximal inhibitory concentration: 14500 nM
Compound 4: middle estimate off by 1.5-fold (0.16 log units), on the low side; the measured number falls inside the stated range.
By their numbers in this assay, from the lowest: compounds 3, 1, 4 and 2 (each within the scatter of the next).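

In this assay, within the data shown here, the change to 3-fluorophenyl gives the first reading on a substitution of this phenyl ring: fluoro in place of hydrogen on an aromatic carbon, meta to a large group, gives a 1.4-fold higher number from compound 3 to compound 4 (0.14 log units; within the scatter) and so cannot be told from no change. The exchanges on the carbonyl carbon now extend to this fluorinated ring, and a 1.4-fold lower number from compound 2 to compound 4 (0.15 log units; within the scatter) and a 1.1-fold higher number from compound 1 to compound 4 (0.04 log units; within the scatter) also leave compound 4 inseparable from both compounds with an amine in that group. Among these compounds, no order among the compounds follows from these steps.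

From the compounds shown here alone, whether a chloro, a methoxy or a nitrile in place of this fluoro would give a step beyond the scatter stays open. Nothing available bears on the reason for these readings.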